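Fluoro to Chloro on an Aromatic Carbon

A few compounds are considered here, and "the series" means these few. Any claim that something is new, unique, unknown or untested is made for them only; others in the source may bear on it.

In a functional assay on HepG2 cells (Homo sapiens) for inhibition, read by MTT assay (on this read-out lower numbers stand for stronger inhibition and higher numbers for weaker inhibition), compound 1 `COc1cc2ncnc(Nc3ccc(NC(=O)c4ccccc4F)cc3)c2cc1OC` gives 13000 nM and compound 2 `COc1cc2ncnc(Nc3ccc(NC(=O)c4cccc(F)c4)cc3)c2cc1OC` gives 8200 nM. Going by the values given here, compound 2 therefore stands level with compound 1, its only measured neighbour. Compound 3 `COc1cc2ncnc(Nc3ccc(NC(=O)c4cccc(Cl)c4)cc3)c2cc1OC` carries chloro in place of fluoro on an aromatic carbon. Among the compounds with values here, no measured pair tests this swap directly. The nearest guide is a 1.6-fold lower number from compound 1 to compound 2 (0.20 log units; within the scatter), which lies within the scatter and involves only a relocated fluoro group. No step beyond the scatter is therefore expected in this assay. The expected step is small, a 1.1-fold lower number from compound 2 to compound 3 (0.04 log units; within the scatter). Compound 3 is estimated at 7500 nM, within a range of 3500 nM to 16000 nM.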

Compound 3, half-maximal inhibitory concentration: 12000 nM
Compound 3: middle estimate off by 1.6-fold (0.20 log units), on the low side; low and high end bracket the measured number.
By their numbers in this assay, from the lowest: compounds 2, 3 and 1 (each within the scatter of the next).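

Here the halogen itself is exchanged rather than moved: chloro in place of fluoro on this aromatic carbon gives a 1.5-fold higher number from compound 2 to compound 3 (0.17 log units; within the scatter) in this assay. Setting 3-chlorophenyl against 2-fluorophenyl gives a 1.1-fold lower number from compound 1 to compound 3 (0.03 log units; within the scatter), so compounds 1, 2 and 3 all stand level, and neither swapping this halogen nor moving fluoro separates them. Nothing measured here explains these numbers. Still open, as far as these compounds go, is whether an amine, a methoxy group or a carboxylic acid in this place on the ring would give a number beyond the scatter of these three.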